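Chloro for hydrogen on the aryl ring of compound 1

This account rests on a few compounds, and the source may have more. Where it says the series, first, only, none or still open, it means among the compounds named here.

Working notes on the series. Compound 1 `O=C1N=C(C2C(=O)c3ccccc3C2=O)CC(c2ccccc2)N1` stands lowest of the three numbers in a functional assay on the whole organism for inhibition, with Rattus norvegicus as the target, read by paw edema, with stated times of 30 min and 4 h, at a dose of 10 mg/kg by the oral route; a higher number here means more inhibition at the dose given (going by the name of the read-out), a lower number less inhibition: compound 1 gives 11%. Compound 2 `O=C1N=C(C2C(=O)c3ccccc3C2=O)CC(c2cccc([N+](=O)[O-])c2)N1` gives 12%, and compound 3 `O=C1N=C(C2C(=O)c3ccccc3C2=O)CC(c2ccc([N+](=O)[O-])cc2)N1` gives 18%, as the steps of a number 1 percentage points higher from compound 1 to compound 2 (within the scatter) and a number 7 percentage points higher from compound 1 to compound 3 (within the scatter) show. Compound 4 `O=C1N=C(C2C(=O)c3ccccc3C2=O)CC(c2ccc(Cl)cc2)N1` differs from compound 1 in one place: chloro in place of hydrogen on an aromatic carbon. The measured steps that bear on this both put a nitro in place of hydrogen on an aromatic carbon, and neither moved the read-out beyond the scatter; the step of a number 6 percentage points higher from compound 2 to compound 3 (within the scatter) is likewise within it. Hence for compound 4 no step beyond the scatter is expected in this assay, a number 4 percentage points higher from compound 1 to compound 4 (within the scatter). Compound 4 is estimated at 15%, with a range from 5% to 28%.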

Compound 4, a percentage reported as inhibition, in the whole organism at one dose (the size of the read-out at that dose, not a potency): 34%
Compound 4: the middle estimate sits 19 percentage points below what was measured; the whole stated range lies below it.
By their numbers in this assay, from the lowest: compounds 1, 2 and 3 (each within the scatter of the next); then compound 4.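

At the aromatic carbon para to a large group, the read-out in this assay can move beyond the scatter: chloro for hydrogen gives a number 23 percentage points higher from compound 1 to compound 4 (beyond the scatter) here, which the nitro steps did not show. The entering group matters at this place, with a number 16 percentage points higher from compound 3 to compound 4 (beyond the scatter) for chloro in place of nitro and a number 22 percentage points higher from compound 2 to compound 4 (beyond the scatter) for 4-chlorophenyl in place of 3-nitrophenyl. Nothing at hand accounts for this gain.

As far as these compounds go, whether fluoro, bromo, methyl or methoxy at this place would match chloro remains open. So does whether the gain holds for chloro elsewhere on the aryl ring.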